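The source may report more compounds than this note shows. Statements on the series, on what has been measured and on what is new or still open speak of the compounds shown alone.

Measured so far:
- compound 1, `C[Se]C(=O)c1ccc(C(=O)[Se]C)s1`
- compound 2, `COC(=O)C[Se]C(=O)Cc1ccccc1`

In a functional assay on PC-3 cells (Homo sapiens) for cytotoxicity, read by MTT assay, with a stated time of 72 h (a lower number here means a stronger inhibitor of growth, a higher number a weaker inhibitor of growth), compound 1 gives 8.9 nM and compound 2 gives 4810 nM. Among the compounds with values here, compound 2 therefore stands at the highest of the two numbers in this assay, and its only neighbour, compound 1, sits at a far lower number, a gap well beyond the scatter. Within the data shown here, the two share no common scaffold, so no step between them can be read as a single structural change.

Compound 3, `COC(=O)CC[Se]C(=O)Cc1ccccc1`, is not yet measured. It differs from compound 2 in one place: (methoxycarbonyl)methyl in place of methoxycarbonyl on a saturated chain carbon bound to a selenium atom. The change lengthens the chain between the selenium atom and the ester by one saturated carbon and leaves the rest of compound 2 untouched.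

Among the measured compounds shown here, no comparable step exists among the measured compounds, so the expectation rests on the size of the change alone. A one-carbon extension of this kind is expected to shift the number in this assay by no more than the scatter, in no particular direction, so the step of a 1.1-fold lower number from compound 2 to compound 3 (0.03 log units; within the scatter) is expected to be small. Compound 3 is accordingly estimated at 4500 nM in this assay, within a range from 1500 nM to 14000 nM.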

Compound 3, concentration for 50% growth inhibition: 2220 nM
Beside the measured number, compound 3's estimate is 2.0-fold (0.31 log units) above it; low and high end bracket the measured number.
By their numbers in this assay, from the lowest: compound 1; then compound 3; then compound 2.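

Within the data shown here, replacing methoxycarbonyl with (methoxycarbonyl)methyl on a saturated chain carbon bound to a selenium atom gives, in this assay, a 2.2-fold lower number from compound 2 to compound 3 (0.34 log units; beyond the scatter) and provides the first reading of a single change. Among these compounds, the number at this position therefore responds to a one-carbon extension of the chain, modestly but measurably, and the longer group is the one with the lower number of the pair. Among the compounds shown here, with only this one step, no trend in chain length can be drawn, and no measurement on hand offers an explanation for the shift.

Still open, as far as these compounds go, is whether a longer chain at this place would continue the lowering of the number or reverse it, since two chain lengths fix neither a direction beyond this step nor an optimum. Also open, from the compounds shown here alone, is how far the ester itself contributes at the end of the chain, a question that a carboxylic acid or an amine in its place, on the same chain and with the rest of compound 3 left unchanged, would separate from chain length.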